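Changing the benzyl substituent on an aminated aryl core

This account rests on a few compounds, and the source may have more. Where it says the series, first, only, none or still open, it means among the compounds named here.

compound 1, `Nc1cc(N)c2nc(-c3ccccc3)c(NCc3ccc(Cl)c(Cl)c3)nc2c1`: 38900 nM
compound 2, `CCOC(=O)[C@H](CCC(=O)O)NC(=O)c1ccc(Oc2nc3cc(N)cc(N)c3nc2-c2ccccc2)cc1`: < 100000 nM

Within the data shown here, compound 1 is the only compound here with a proper number: in a functional assay on EKVX cells (Homo sapiens) for inhibition, read by sulforhodamine B assay, with a stated time of 48 h (a lower number here means a stronger inhibitor of growth, a higher number a weaker inhibitor of growth), compound 1 gives 38900 nM. Compound 2 returns only a limit, < 100000 nM, which is not a number. Compound 1 therefore stands alone as the sole measured point of reference, with the other entry sitting at the limit of < 100000 nM in this assay, at which 1 of the 2 values shown sits.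

Compound 3, `COc1ccc(CNc2nc3cc(N)cc(N)c3nc2-c2ccccc2)cc1`, shares the core of compound 1 and differs in a single place: 4-methoxyphenyl in place of 3,4-dichlorophenyl on a saturated chain carbon bound to a nitrogen on an aromatic ring. Among the measured compounds shown here, no step between two measured compounds is available to calibrate this change, so any expectation rests on compound 1 alone. The exchange of 3,4-dichlorobenzyl for 4-methoxybenzyl is expected to move the concentration for total growth inhibition only modestly, if at all, and with no confident direction; a step from compound 1 to compound 3 of about a 1.4-fold higher number from compound 1 to compound 3 (0.15 log units; within the scatter) is the estimate, close to the usual scatter. Compound 3 is accordingly expected to give about 55000 nM, within a range of 18000 nM to 100000 nM.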

Compound 3, concentration for total growth inhibition: 28200 nM
The estimate for compound 3 lay 2.0-fold (0.29 log units) above the measured number, and the stated range covers the measured number.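

In this assay, the exchange of 3,4-dichlorophenyl for 4-methoxyphenyl on a saturated chain carbon bound to a nitrogen on an aromatic ring gives a 1.4-fold lower number from compound 1 to compound 3 (0.14 log units; within the scatter), the first step available at this position. Compound 1 and compound 3 therefore cannot be ranked: this one change, which replaces a group without a hydrogen-bond acceptor by one with a hydrogen-bond acceptor, leaves the concentration for total growth inhibition within the scatter, and the pair shows that this position has accepted two different substituted phenyl groups with no measurable change in this read-out. No measured property in the data bears on this result, and no explanation can be drawn for it.

Going by these compounds, whether a carboxylic acid or an amine on the phenyl ring, or a longer chain in place of the single saturated carbon, would produce a step beyond the scatter remains open. Among these compounds, compound 2 carries only a limit, which is not a number, and it offers no step at this position or any other.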